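This account rests on a few compounds, and the source may have more. Where it says the series, first, only, none or still open, it means among the compounds named here.

Measured compounds in this assay:
compound 1 `O=C(O)c1ccccc1C1CC(c2cc3ccccc3o2)=NN1C(=O)c1ccncc1` — > 170000 nM
compound 2 `O=C(c1ccncc1)N1N=C(c2cc3ccccc3o2)CC1c1ccc(Cl)cc1` — > 220000 nM
compound 3 `CCn1cc(C(=O)N2N=C(c3cc4ccccc4o3)CC2c2ccccc2O)c(=O)c2ccc(C)nc21` — > 157000 nM

In an ADME assay on Vero cells (Chlorocebus sabaeus) for cytotoxicity, read by MTT assay, with a stated time of 72 h (a higher number here means a weaker inhibitor, a lower number a stronger inhibitor), compound 1 gives > 170000 nM, which is a limit of the assay and not a number. Compound 2 gives > 220000 nM, likewise a limit. Compound 3 gives > 157000 nM, also a limit. Compound 3 therefore stands at the limit of > 157000 nM in this assay, at which 1 of the 3 values shown sits. The other two values sit at the limit of > 170000 nM in this assay, at which 1 of the 3 values shown sits, and (the limit of > 220000 nM in this assay, at which 1 of the 3 values shown sits). No value among the three is a number, so no ordering of the three compounds can be read.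

Going by the values given here, the only step between measured compounds, a step that the two limits leave unreadable from compound 1 to compound 2, is unreadable: the two limits bound it on neither side.

Compound 4 `CCn1cc(C(=O)N2N=C(c3cc4ccccc4o3)CC2c2ccccc2C(=O)O)c(=O)c2ccc(C)nc21` differs from compound 3 by carboxy in place of hydroxy on an aromatic carbon. Among the compounds with values here, the one measured step that touches this position gives no size, and compound 1, which carries the same 2-carboxyphenyl group on the shared core, also sits at a limit with > 170000 nM. Within the data shown here, no measured step therefore points to movement beyond the scatter; the expected step that the limit leaves unreadable from compound 3 to compound 4 is none beyond the scatter. Compound 4 is expected at 200000 nM, with a range of 100000 nM to 500000 nM, and most probably again reported only as a limit.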

Compound 4, half-maximal inhibitory concentration: > 196000 nM
Compound 4 ended at the assay's limit; the forecaster's own chance of this, stated with the estimate: 85%; the middle value is on the limit's open side.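

In this assay compound 4 gives > 196000 nM, which is a limit of the assay and not a number. Compound 3 also stands only at a limit, so the step between compound 3 and compound 4 cannot be read. The compounds shown leave open where any of the four would give an actual number in this assay, and whether carboxy in place of hydroxy moves it.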